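A few compounds are considered here, and "the series" means these few. Any claim that something is new, unique, unknown or untested is made for them only; others in the source may bear on it.

In a functional assay on HCT-116 cells (Homo sapiens) for cytotoxicity, read by MTT assay, with a stated time of 72 h (on this read-out higher numbers stand for weaker inhibition and lower numbers for stronger inhibition), compound 1 `O=C(NCc1ccc(F)cc1)c1nc(NCCO)c2cccnc2c1O` stands as "not determined" (no result reported) and gives no number. Compound 2 `Nc1cccc(Nc2c(C(=O)NCc3ccc(F)cc3)nc(Br)c3cccnc23)c1` reads > 10000 nM and this is a limit, not a number. Compound 3 `CC(C)(C)OC(=O)N1CCN(c2c(C(=O)NCc3ccc(F)cc3)nc(Br)c3cccnc23)CC1` reads > 10000 nM and this too is a limit. Compound 2 therefore stands at the limit of > 10000 nM in this assay, at which 2 of the 3 values shown sit, and offers no exact starting point. Compound 4 `Nc1ccc(Nc2c(C(=O)NCc3ccc(F)cc3)nc(Br)c3cccnc23)cc1` differs from compound 2 by 4-aminophenyl in place of 3-aminophenyl on a nitrogen on an aromatic ring with 4-aminophenyl in place of 3-aminophenyl on a nitrogen on an aromatic ring. Among the measured compounds shown here, the series holds no measured step for sizing this change, so no shift beyond the scatter is expected. The estimated a number no higher from compound 2 to compound 4 (the limit leaves the size open) is expected to show no clear direction. For compound 4 the estimate is 10000 nM with 3000 nM to 30000 nM as the expected range.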

Compound 4, half-maximal inhibitory concentration: 7000 nM
Compound 4: the middle estimate sits 1.4-fold (0.15 log units) above what was measured; the range from low to high includes it.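

In this assay, 4-aminophenyl in place of 3-aminophenyl on a nitrogen on an aromatic ring gives an at least 1.4-fold lower number from compound 2 to compound 4 (0.15 log units; that floor lies within the scatter). Among the compounds shown here, compound 4 supplies the first exact value at this position, 7000 nM, so the series now has a number to measure further changes against. The true size of the step stays unknown, as compound 2 gives only a limit: the limit of > 10000 nM in this assay, at which 2 of the 4 values shown sit.

On these data alone, what a carboxylic acid or a dimethylamino group in place of the amine on this phenyl ring would give stays open. So does the effect of a longer chain on the same nitrogen.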